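Trading Butoxy for Propyl on the Shared Core

A few compounds are considered here, and "the series" means these few. Any claim that something is new, unique, unknown or untested is made for them only; others in the source may bear on it.

Compound 2 `CCCCOc1cccc(C(=O)Nc2nn[nH]n2)n1` gives 8% in a functional assay on the whole organism for inhibition, with Rattus norvegicus as the target, at a dose of 10 mg/kg by the oral route; a lower number here means a weaker effect, a higher number a stronger effect of the compound at the dose given. Going by the values given here, the only other measured compound, compound 1 `O=C(Nc1nn[nH]n1)c1cccc(Oc2ccccc2)n1`, gives 0% in this assay, and the step of a number 8 percentage points higher from compound 1 to compound 2 (within the scatter) lies within the scatter, so the two numbers show only that both effects are small. Compound 3 `CCCc1cccc(C(=O)Nc2nn[nH]n2)n1` differs from compound 2 by propyl in place of butoxy on an aromatic carbon. Among the compounds with values here, no measured step bears on this change; the single known step concerns a different group and stays within the scatter. Compound 3 is therefore expected to stay close to compound 2, with an estimated step of a number 2 percentage points lower from compound 2 to compound 3 (within the scatter). Compound 3 is estimated at 6%, with a range from 0% to 25%.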

Compound 3, a percentage reported as inhibition, in the whole organism at one dose (the size of the read-out at that dose, not a potency): 38%
Compound 3: the middle estimate sits 32 percentage points below what was measured; measured number outside the range, above it.
By their numbers in this assay, from the lowest: compounds 1 and 2 (each within the scatter of the next); then compound 3.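

Propyl in place of butoxy gives a number 30 percentage points higher from compound 2 to compound 3 (beyond the scatter) in this assay and propyl in place of phenoxy gives a number 38 percentage points higher from compound 1 to compound 3 (beyond the scatter) on the shared core, so this position can respond strongly to a change of group. Both steps replace a group joined through oxygen with a chain joined through carbon, whereas the step between the two oxygen-joined groups stayed within the scatter. Nothing measured here explains the rise. The compounds shown leave open whether the lost oxygen or the shorter chain carries the step. A butyl or ethyl chain, or an amine, at this position would help to separate these.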